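This account rests on a few compounds, and the source may have more. Where it says the series, first, only, none or still open, it means among the compounds named here.

Among the measured compounds shown here, compound 1 `COc1ccc(/C=N/NC(=O)Nc2ccc(Oc3ccnc4cc(OCCCN5CCCCC5)c(OC)cc34)c(F)c2)cc1` gives 590 nM in a functional assay on HT-29 cells (Homo sapiens) for cytotoxicity, read by MTT assay, with a stated time of 72 h (a higher number here means a weaker inhibitor, a lower number a stronger inhibitor), the lowest of the two numbers so far. For the measured compounds named here, compound 2 `COc1cc2c(Oc3ccc(NC(=O)N/N=C/c4ccc(N(C)C)cc4)cc3F)ccnc2cc1OCCCN1CCCCC1` gives 1000 nM, and the step of a 1.7-fold higher number from compound 1 to compound 2 (0.23 log units; within the scatter) is the only measured comparison. Compound 3 `COc1cc2c(Oc3ccc(NC(=O)N/N=C/c4cc5ccccc5[nH]4)cc3F)ccnc2cc1OCCCN1CCCCC1` differs from compound 1 by 1H-indol-2-yl in place of 4-methoxyphenyl on a carbon with a double bond to nitrogen. Going by the values given here, no measured step bears on this exchange of the whole aryl group; the one step known, from a substituent change on the same ring, stayed within the scatter, so nothing beyond the scatter is expected for the step of a 1.2-fold higher number from compound 1 to compound 3 (0.07 log units; within the scatter), with a wide uncertainty. Compound 3 is estimated at 700 nM, between 250 nM and 2000 nM.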

Compound 3, half-maximal inhibitory concentration: 820 nM
For compound 3 the middle estimate is 1.2-fold (0.07 log units) below the measured one, within the range that was stated.
By their numbers in this assay, from the lowest: compounds 1, 3 and 2 (each within the scatter of the next).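

On the carbon with a double bond to nitrogen, the whole aryl group can be exchanged, not only a substituent on it, without leaving the scatter of this assay: 1H-indol-2-yl in place of 4-methoxyphenyl gives (a 1.4-fold higher number from compound 1 to compound 3 (0.14 log units; within the scatter)), and in place of 4-(dimethylamino)phenyl gives (a 1.2-fold lower number from compound 2 to compound 3 (0.09 log units; within the scatter)). A five-membered aromatic ring and a hydrogen-bond donor thus enter with all three compounds within the scatter of one another. No evidence bears on this result.

Still open, going by these compounds, is whether a saturated cyclohexyl group or a pyridyl ring here would give a step beyond the scatter. Also open, on these data alone, is whether a carboxylic acid on the aryl ring would do so.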